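A few compounds are considered here, and "the series" means these few. Any claim that something is new, unique, unknown or untested is made for them only; others in the source may bear on it.

Working notes on the series, all read in an ADME assay on cells (Macrophage) for cytotoxicity, read by resazurin assay, with a stated time of 48 h (on this read-out higher numbers stand for lower toxicity in this test and lower numbers for higher toxicity in this test), for now. Compound 1 (`CCCCCCn1cc(COc2ccc(-c3cc(-c4cccc5ccccc45)nc(N)n3)c(O)c2)nn1`) has the entry "not determined" (no result reported) and so gives no number to start from. Compound 2 (`CCCCCCn1cc(COc2ccc(-c3cc(-c4c(F)cccc4Cl)nc(N)n3)c(O)c2)nn1`) has the entry "not determined" (no result reported) as well. Within the data shown here, the only number comes from compound 3 (`CCCCCCn1cc(COc2ccc(-c3cc(-c4ccc(Cl)cc4)nc(N)n3)c(O)c2)nn1`), at 30300 nM in this assay. Compound 4 (`Nc1nc(-c2ccc(OCc3cn(Cc4ccc(Br)cc4)nn3)cc2O)cc(-c2cccc3ccccc23)n1`) is unmeasured. The structural change is 4-bromophenyl in place of pentyl on a saturated chain carbon bound to an aromatic nitrogen and amounts to hexyl to 4-bromobenzyl. Among the measured compounds shown here, no measured step exists to size it, so no shift beyond the usual scatter is expected, in either direction, from the level of compound 3 at 30300 nM as the sole anchor. Compound 4 is estimated at 25000 nM with an expected range from 8000 nM to 60000 nM in this series.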

Compound 4, half-maximal cytotoxic concentration: > 100000 nM
Compound 4: no number, only a limit; the forecaster's own chance of this, stated with the estimate: 20%; middle value at least 4.0-fold (0.60 log units) away from the limit.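

No step can be read between compound 1 and compound 4: compound 1 has no number, and compound 4 gives only a limit. Going by these compounds, the size of the change from hexyl to 4-bromobenzyl on its own stays open.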